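Thiazolidinedione amides: moving from compound 2 to compound 3

A few compounds are considered here, and "the series" means these few. Any claim that something is new, unique, unknown or untested is made for them only; others in the source may bear on it.

Measured compounds in an assay on isolated protein for inhibition of histone deacetylase 4 (Homo sapiens), with a stated time of 1 h; a lower number here means a stronger inhibitor, a higher number a weaker inhibitor:
compound 1, `O=C(COc1ccc2cc(/C=C3/SC(=O)NC3=O)ccc2c1)Nc1cccc(F)n1`, 840 nM;
compound 2, `O=C(COc1ccc2cc(/C=C3/SC(=O)NC3=O)ccc2c1)Nc1cccc(Cl)c1`, 3800 nM.

Compound 2 gives the higher of the two numbers, and the step of a 4.5-fold higher number from compound 1 to compound 2 (0.66 log units; beyond the scatter) lies beyond the scatter. Compound 3, `O=C(COc1ccc2cc(/C=C3/SC(=O)NC3=O)ccc2c1)Nc1ccc(Br)cc1`, differs from compound 2 by 4-bromophenyl in place of 3-chlorophenyl on an amide-type nitrogen. For the measured compounds named here, no measured step covers this exchange of one halogenated phenyl for another; the only step known swaps an aryl of a different kind. Compound 3 is therefore expected to stay close to compound 2, with a step of a 1.1-fold lower number from compound 2 to compound 3 (0.04 log units; within the scatter), and the estimate for compound 3 is 3500 nM, spanning 1200 nM to 10000 nM.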

Compound 3, half-maximal inhibitory concentration: 2900 nM
Compound 3: middle estimate off by 1.2-fold (0.08 log units), on the high side; the measured number falls inside the stated range.
By their numbers in this assay, from the lowest: compound 1; then compounds 3 and 2 (each within the scatter of the next).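

In this assay, 4-bromophenyl in place of 3-chlorophenyl on the amide-type nitrogen gives a 1.3-fold lower number from compound 2 to compound 3 (0.12 log units; within the scatter) and so does not separate these two halogenated phenyl groups. The change from the 6-fluoropyridin-2-yl of compound 1 gives a 3.5-fold higher number from compound 1 to compound 3 (0.54 log units; beyond the scatter) and thus also holds for a second halogenated phenyl, leaving compound 1 apart from both. No evidence bearing on the reason for these numbers is available.

Still open, as far as these compounds go, is how an unsubstituted phenyl or a 6-chloropyridin-2-yl group would compare on this nitrogen. Such groups could show whether the gap follows the ring nitrogen or the halogen.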